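Hydroxyalkoxy variants on the quinoline ether series: compound 4

The source may report more compounds than this note shows. Statements on the series, on what has been measured and on what is new or still open speak of the compounds shown alone.

Measured so far:
compound 1 `COCCOc1ccc2c(Oc3ccc(Nc4nccc5[nH]cc(-c6ccc(F)cc6)c(=O)c45)cc3F)ccnc2c1` — 6500 nM
compound 2 `CC(C)(O)COc1ccc2c(Oc3ccc(Nc4nccc5[nH]cc(-c6ccccc6)c(=O)c45)cc3F)ccnc2c1` — 4200 nM
compound 3 `O=c1c(-c2ccc(F)cc2)c[nH]c2ccnc(Nc3ccc(Oc4ccnc5cc(OCCO)ccc45)c(F)c3)c12` — 5500 nM

All three were run in a functional assay on HT-29 cells (Homo sapiens) for antiproliferative activity, read by MTT assay, with a stated time of 72 h; on this read-out higher numbers stand for weaker inhibition and lower numbers for stronger inhibition. Compound 1 gives 6500 nM and sits at the upper end of the three numbers, though neither neighbour is separated from it beyond the scatter: compound 3 is nearest and compound 2 furthest, and both gaps fall within the usual spread of repeats.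

Compound 4 `CC(O)COc1ccc2c(Oc3ccc(Nc4nccc5[nH]cc(-c6ccc(F)cc6)c(=O)c45)cc3F)ccnc2c1` is the next member awaiting a number. It differs from compound 1 as follows: 1-hydroxyethyl in place of methoxymethyl on a saturated chain carbon bound to an oxygen on an aromatic ring. Cut one bond further out, the change reads 2-methoxyethoxy to 2-hydroxypropoxy.

For the measured compounds named here, the only measured step that bears on it is the one between compound 1 and compound 3, where the same oxygen loses its methyl: a 1.2-fold lower number from compound 1 to compound 3 (0.07 log units; within the scatter). That step did not move the number beyond the scatter. Compound 2 carries a related 2-hydroxy-2-methylpropoxy chain but also lacks the fluorine on the pendant ring, so its value only shows that such chains stay in the same range.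

On that basis no step beyond the scatter is expected for compound 4 in this assay; its value is estimated at 5000 nM, within 2500 nM to 10000 nM, which amounts to an expected step of a 1.3-fold lower number from compound 1 to compound 4 (0.11 log units; within the scatter).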

Compound 4, half-maximal inhibitory concentration: 3900 nM
For compound 4 the middle estimate is 1.3-fold (0.11 log units) above the measured one, and the stated range covers the measured number.
By their numbers in this assay, from the lowest: compounds 4, 2, 3 and 1 (each within the scatter of the next).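

In this assay, the change from 2-methoxyethoxy to 2-hydroxypropoxy gives a 1.7-fold lower number from compound 1 to compound 4 (0.22 log units; within the scatter), so exchanging methoxymethyl for 1-hydroxyethyl, with the hydrogen-bond donor count going from 0 to 1, produces no step beyond the scatter at this position. The second new comparison adds what the earlier methyl-to-hydrogen step could not show: a methyl on the saturated chain carbon gives a 1.4-fold lower number from compound 3 to compound 4 (0.15 log units; within the scatter), so this place on the chain also shows no step beyond the scatter, and the three fluorophenyl compounds with these chains cannot be ranked in this assay. Nothing available gives a reason for these results or bears on them.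

From the compounds shown here alone, whether this flat response holds for chains of another type stays open: an amine or a carboxylic acid in place of the hydroxyl of the 2-hydroxypropoxy chain, or a longer chain, could still give a step beyond the scatter. Compound 2 differs from compound 4 in two places, in its chain and in the fluorine on the pendant ring, so the contribution of that fluorine cannot be read from the compounds shown.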